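Same pyridyl swap on two cores: what to expect

The compounds below may be only part of what the source reports. "The series", "measured", "known", "first", "only" and "open" are said of these compounds alone.

Three compounds have been measured in a functional assay on CHO cells for positive allosteric modulation of metabotropic glutamate receptor 2 (Homo sapiens), read by scintillation counting and GTPgammaS binding, with a stated time of 30 min; a higher number here means a larger maximal response, a lower number a smaller maximal response:

compound 1, `Cc1cc(Oc2ccc(-c3ccn(CCC(C)C)c(=O)c3C#N)cc2)ccn1`, gives 266%
compound 2, `Cc1ncccc1Oc1ccc(-c2ccn(CCC(C)C)c(=O)c2C#N)cc1`, gives 256%
compound 3, `CCCCn1ccc(-c2ccc(Oc3ccnc(C)c3)c(Cl)c2)c(C#N)c1=O`, gives 245%

Compound 1 and compound 2 share a core and differ only in one place: 2-methylpyridin-3-yl in place of 2-methylpyridin-4-yl on an oxygen on an aromatic ring. The step that goes with this change is a number 10 percentage points lower from compound 1 to compound 2 (within the scatter). Compound 3 is built on a different core; the difference between the core of compound 1 and the core of compound 3 is not broken down here, and compound 3 stands lowest of the three numbers, beyond the scatter from both compound 1 and compound 2.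

Compound 4, `CCCCn1ccc(-c2ccc(Oc3cccnc3C)c(Cl)c2)c(C#N)c1=O`, has not been measured. It differs from compound 3 by the same kind of change, (2-methylpyridin-3-yl in place of 2-methylpyridin-4-yl on an oxygen on an aromatic ring), at a place described in the same words as before, so the pair compound 3 and compound 4 repeats the change seen between compound 1 and compound 2.

The step from compound 3 to compound 4 in this assay is expected to be a number 10 percentage points lower from compound 3 to compound 4 (within the scatter), small and within the scatter, because the same change gave a number 10 percentage points lower from compound 1 to compound 2 (within the scatter). Compound 4 is therefore estimated at 235%, with a likely range from 205% to 265%.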

Compound 4, largest response reached (Emax), in percent of the reference or control that the assay uses: 236%
For compound 4 the middle estimate is 1 percentage points below the measured one; measured number inside the range.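

In this assay, putting 2-methylpyridin-3-yl in place of 2-methylpyridin-4-yl on the oxygen gives a number 9 percentage points lower from compound 3 to compound 4 (within the scatter) on the core of compound 3. Set side by side, the steps on the two cores do not differ: the same change on two cores in this assay, a number 10 percentage points lower (within the scatter) from compound 1 to compound 2 and a number 9 percentage points lower (within the scatter) from compound 3 to compound 4, 1 percentage points apart, within the scatter of two such steps. This shows that, in these two pairs, the change carries from one core to the other with the same small step in the largest response reached, but two pairs on two cores make no rule for the whole series, and they do not show why the step is small or how the change behaves in any other read-out.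

The compounds shown leave open whether the same step would appear on a third core. They also leave open what happens on the oxygen with a pyridine that lacks the methyl group, or with an amine, a carboxylic acid or a longer chain in place of that methyl group.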